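Replacing 4-methylpiperidin-1-yl with (4-fluorophenyl)amino in compound 3

A few compounds are considered here, and "the series" means these few. Any claim that something is new, unique, unknown or untested is made for them only; others in the source may bear on it.

Compound 1 `CC(C)(C#N)NC(=O)[C@@H]1C[C@@H](S(=O)(=O)c2ccccc2)C[C@H]1C(=O)N1CCOCC1`: 43 nM
Compound 2 `N#CC1(NC(=O)[C@@H]2C[C@@H](S(=O)(=O)c3ccccc3)C[C@H]2C(=O)N2CCOCC2)CCC1`: 236 nM
Compound 3 `CC1CCN(C(=O)[C@@H]2C[C@H](S(=O)(=O)c3ccccc3)C[C@H]2C(=O)NC2(C#N)CC2)CC1`: 2 nM

In a functional assay on A20 cells (Mus musculus) for inhibition, with stated times of 1 h, 16 h and 24 h (a higher number here means a weaker inhibitor, a lower number a stronger inhibitor), compound 3 stands lowest of the three at 2 nM, while compound 1 gives 43 nM and compound 2 gives 236 nM. Compound 4 `N#CC1(NC(=O)[C@@H]2C[C@@H](S(=O)(=O)c3ccccc3)C[C@H]2C(=O)Nc2ccc(F)cc2)CC1` has not yet been measured. It differs from compound 3 in one place, on a carbonyl carbon whose other neighbour is a saturated ring carbon: (4-fluorophenyl)amino in place of 4-methylpiperidin-1-yl on a carbonyl carbon. A six-membered non-aromatic ring with a hetero atom thus gives way to a six-membered aromatic ring of carbon only, and a hydrogen-bond donor enters.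

For the measured compounds named here, no measured step covers this place. The only one available, a 5.5-fold higher number from compound 1 to compound 2 (0.74 log units; beyond the scatter), is a change on an amide-type nitrogen elsewhere in the molecule, so it serves only as a rough gauge of size. Going by the values given here, with compound 3 holding the lowest number so far at 2 nM, a step of similar modest size towards a higher number is expected, although a step within the scatter cannot be ruled out. The expected change is a 5.0-fold higher number from compound 3 to compound 4 (0.70 log units; beyond the scatter). For compound 4 the estimated value is 10 nM, with an expected range from 2 nM to 60 nM.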

Compound 4, half-maximal inhibitory concentration: 391 nM
Beside the measured number, compound 4's estimate is 39-fold (1.59 log units) below it, outside the stated range (above it).
By their numbers in this assay, from the lowest: compound 3; then compound 1; then compounds 2 and 4 (each within the scatter of the next).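

In this assay, for the compounds shown here, the carbonyl carbon proves to be a far more sensitive place than the only earlier step suggested: the exchange gives a 200-fold higher number from compound 3 to compound 4 (2.29 log units; beyond the scatter) and counts as large, whereas the change on the amide-type nitrogen gave a 5.5-fold higher number from compound 1 to compound 2 (0.74 log units; beyond the scatter) and counted only as modest. The low number of compound 3 is therefore not kept when 4-methylpiperidin-1-yl gives way to (4-fluorophenyl)amino, so this place does not accept any six-membered ring equally well. No measurement at hand gives a reason for the size of this step.

The exchange replaces the non-aromatic ring with an aromatic one and brings in a hydrogen-bond donor in a single move, so the compounds shown cannot tell which of these changes accounts for the step. Going by these compounds, a cyclohexylamino group would keep a saturated ring alongside the amide hydrogen, while a methyl(4-fluorophenyl)amino group would keep the aromatic ring without that hydrogen, and how either would read in this assay remains open.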